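The source may report more compounds than this note shows. Statements on the series, on what has been measured and on what is new or still open speak of the compounds shown alone.

Compound 1 `Cc1ccc2c(NCc3ccc(NC(=O)C4CCN(Cc5ccccc5)CC4)cc3)nc(N3CCC3)nc2c1` belongs to a small set of three measured compounds. In a functional assay on SV5A8 cells (Homo sapiens) for cytotoxicity (on this read-out lower numbers stand for stronger inhibition and higher numbers for weaker inhibition), compound 1 gives > 8500 nM, which is a limit of the assay rather than a measured number. Compound 2 `Cc1ccc2c(NCc3ccc(NC(=O)C4CCN(Cc5ccc(Cl)cc5)CC4)cc3)nc(N(C)C)nc2c1` gives > 3180 nM in this assay, also a limit. Compound 3 `Cc1ccc(CN2CCC(C(=O)Nc3ccc(CNc4nc(N(C)C)nc5cc(C)ccc45)cc3)CC2)cc1` gives > 4150 nM in this assay, again a limit. The only change among these compounds confined to one place, from compound 2 to compound 3, is a step that the two limits leave unreadable from compound 2 to compound 3, a methyl in place of chloro on an aromatic carbon; with both of its ends at a limit its size cannot be read. Compound 1 thus stands at a limit, and the two other values shown are limits as well.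

Compound 4 `CCNc1nc(NCc2ccc(NC(=O)C3CCN(Cc4ccccc4)CC3)cc2)c2ccc(C)cc2n1` differs from compound 1 by ethylamino in place of azetidin-1-yl on an aromatic carbon, in words an ethylamino in place of azetidin-1-yl on an aromatic carbon. Among the compounds with values here, no measured step touches this position, and no measured compound differs from compound 1 in a single place, so nothing read here points in either direction. Given that every value shown is a limit, compound 4 is expected to sit near 10000 nM in this assay, within about 3000 nM to 30000 nM, most likely reported again as a limit. The expected step that the limit leaves unreadable from compound 1 to compound 4 is within the scatter.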

Compound 4, half-maximal inhibitory concentration: > 2140 nM
Compound 4 was reported as a limit; the forecaster's own chance of this, stated with the estimate: 75%; the middle value is on the limit's open side.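

Compound 1 and compound 4 are both reported only as limits in this assay, and the step between them, ethylamino in place of azetidin-1-yl, cannot be read. The compounds shown leave open what the actual value of each compound is, and whether changing this group or any other shifts it at all.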